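A few compounds are considered here, and "the series" means these few. Any claim that something is new, unique, unknown or untested is made for them only; others in the source may bear on it.

Compound 1 `Cc1ccc(Oc2ccc(/C=N/NC(=S)Nc3ccccc3)cc2)cc1` gives 5.39 in a physicochemical assay for lipophilicity, in phosphate buffer, measured as octanol-water partition, with a stated time of 24 h; on this read-out lower numbers stand for lower lipophilicity and higher numbers for higher lipophilicity.
Compound 2 `Cc1cc(Oc2ccc(/C=N/NC(=S)Nc3ccc(F)cc3)cc2)ccc1Cl` gives 6.07 in this assay.
Compound 3 `S=C(N/N=C/c1ccc(Oc2ccc3ccccc3c2)cc1)Nc1ccccc1` gives 6.07 in this assay.

Of the three numbers measured, compound 1 stands lowest. Compound 2 and compound 3 both lie higher, each by a margin beyond the scatter, and the two of them sit at the same value as each other. No two of the measured compounds differ in a single place, so these values are simply three points and tell nothing about any one change on its own.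

Compound 4 `O=[N+]([O-])c1ccc(Oc2ccc(/C=N/NC(=S)Nc3ccccc3)cc2)cc1` has not yet been measured. It differs from compound 1 in one place: nitro in place of methyl on an aromatic carbon, para to a large group. Among the compounds with values here, with no measured pair to draw on for this change, the expectation rests on the structures alone. The step from compound 1 is expected to run downward, with a number 0.79 log units lower from compound 1 to compound 4 (beyond the scatter) as the estimated size, beyond the scatter. Compound 4 is therefore expected to give about 4.6, within a range from 4 to 5.3.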

Compound 4, partition coefficient: 4.95
The estimate for compound 4 lay 0.35 log units below the measured number; measured number inside the range.
By their numbers in this assay, from the lowest: compound 4; then compound 1; then compounds 2 and 3 (each within the scatter of the next).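

Nitro in place of methyl on an aromatic carbon, para to a large group, gives the first comparison in this assay that turns on one change alone, with a number 0.44 log units lower from compound 1 to compound 4 (beyond the scatter). At this position, then, going from 4-methylphenyl to 4-nitrophenyl lowers the read-out by a modest margin, something compound 1, compound 2 and compound 3 could not show, as none of them differ from one another in a single place. Nothing available accounts for the direction or size of this step.

Going by these compounds, whether the same change would run the same way on the core of compound 2 remains open, as this is a single pair at a single position. Also open, on these data alone, is how an amine, a carboxylic acid or a longer alkyl chain would read at this place.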